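A few compounds are considered here, and "the series" means these few. Any claim that something is new, unique, unknown or untested is made for them only; others in the source may bear on it.

Values so far in a functional assay on NB-4 cells (Homo sapiens) for cytotoxicity, read by CCK-8 assay, with a stated time of 24 h; a higher number here means a weaker inhibitor, a lower number a stronger inhibitor:
- compound 1 `C=CC(=O)N1C(=O)CC(C)Sc2ccccc21` gives 227000 nM
- compound 2 `C=CC(=O)N1C(=O)CC(c2ccc(Cl)cc2)Sc2ccccc21` gives 22600 nM
- compound 3 `C=CC(=O)N1C(=O)CC(c2ccccc2Cl)Sc2ccccc21` gives 33800 nM

Compound 2 sits at the low end of these numbers, not separated from its closest neighbour (a 1.5-fold higher number from compound 2 to compound 3 (0.17 log units; within the scatter)) and well clear of the methyl member (a 10-fold lower number from compound 1 to compound 2 (1.00 log units; beyond the scatter)). The change to compound 4 `C=CC(=O)N1C(=O)CC(c2ccc(C(=O)OC)cc2)Sc2ccccc21`, not yet measured, is methoxycarbonyl in place of chloro on an aromatic carbon. Among the compounds with values here, no measured step replaces the chloro. Methyl to chlorophenyl gave the larger steps (a 10-fold lower number from compound 1 to compound 2 (1.00 log units; beyond the scatter) and a 6.7-fold lower number from compound 1 to compound 3 (0.83 log units; beyond the scatter)), while moving the chloro gave none beyond the scatter (a 1.5-fold higher number from compound 2 to compound 3 (0.17 log units; within the scatter)). In this assay no step beyond the scatter is therefore expected, on thin evidence. The estimated change is a 1.1-fold higher number from compound 2 to compound 4 (0.04 log units; within the scatter) on this basis. Compound 4 is estimated at 25000 nM (expected range 10000 nM to 60000 nM).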

Compound 4, half-maximal inhibitory concentration: 24400 nM
Compound 4: middle estimate off by 1.0-fold (0.01 log units), on the high side; the measured number falls inside the stated range.
By their numbers in this assay, from the lowest: compounds 2, 4 and 3 (each within the scatter of the next); then compound 1.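

In this assay the first replacement of the chloro itself, on this aromatic carbon para to a large group, leaves the number within the scatter (a 1.1-fold higher number from compound 2 to compound 4 (0.03 log units; within the scatter)). Earlier steps only moved the chloro or replaced methyl, whereas here methoxycarbonyl brings four heavy atoms and two hydrogen-bond acceptors in place of one chlorine. No measurement given here explains why the number holds across this change.

On these data alone, whether an amine or a carboxylic acid at this position would also stay within the scatter remains open. A longer ester chain is equally unresolved.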